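Imidazole for dimethylamine on the side chain

The source may report more compounds than this note shows. Statements on the series, on what has been measured and on what is new or still open speak of the compounds shown alone.

Measured compounds:
compound 1, `O=C1c2c[n+]([O-])c3ccccc3c2C(=O)c2c1c1ccccc1n2Cc1cn([C@H]2O[C@H](CO)[C@@H](O)[C@H]2O)nn1`: 2680 nM
compound 2, `CN(C)CCCCn1c2c(c3ccccc31)C(=O)c1c[n+]([O-])c3ccccc3c1C2=O`: 310 nM

Of the compounds shown here, two sharing one core have been measured in a functional assay on A549 cells (Homo sapiens) for cytotoxicity, read by MTT assay, with a stated time of 72 h; on this read-out higher numbers stand for weaker inhibition and lower numbers for stronger inhibition. Compound 1 carries a sugar-bearing triazolylmethyl group on the core nitrogen and gives 2680 nM. Compound 2 carries a four-carbon chain ending in a dimethylamino group and gives 310 nM, the lower of the two numbers; the gap between compound 2 and compound 1 lies beyond the usual scatter, so compound 2 is the stronger of the pair in this assay.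

Compound 3, `O=C1c2c[n+]([O-])c3ccccc3c2C(=O)c2c1c1ccccc1n2CCCCn1ccnc1`, has not been measured yet. It differs from compound 2 in one place: 1H-imidazol-1-yl in place of dimethylamino on a saturated chain carbon, four bonds along the chain from an aromatic nitrogen. The chain length and the core stay the same. Without a measured step of this kind to lean on, only a modest change is expected, and it is expected to make compound 3 somewhat weaker than compound 2 in this assay, with a step of a 1.8-fold higher number from compound 2 to compound 3 (0.25 log units; within the scatter). Compound 3 is estimated to give 550 nM in this assay, with a likely range from 180 nM to 1700 nM.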

Compound 3, half-maximal inhibitory concentration: 170 nM
Compound 3: the middle estimate sits 3.2-fold (0.51 log units) above what was measured, outside the stated range (below it).
By their numbers in this assay, from the lowest: compounds 3 and 2 (each within the scatter of the next); then compound 1.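

In this assay, placing 1H-imidazol-1-yl where dimethylamino stood at the end of the same chain gives a 1.8-fold lower number from compound 2 to compound 3 (0.26 log units; within the scatter), so this read-out does not separate the two compounds. For this position, on a saturated chain carbon four bonds along the chain from an aromatic nitrogen, the pair shows that an open-chain amine can give way to a five-membered aromatic ring with 2 hetero atoms, with 5 heavy atoms entering where 3 leave, and the numbers stay within the usual scatter of each other. Nothing at hand explains why these two different groups read alike.

As far as these compounds go, what stays open is whether other groups at the end of this chain, such as a morpholine ring, a piperidine ring or a carboxylic acid, would also stay close to these two numbers. From the compounds shown here alone, the chain length is the same in compound 2 and compound 3, so it also remains open whether a shorter or longer chain ending in 1H-imidazol-1-yl would read the same way.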